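The compounds below may be only part of what the source reports. "The series", "measured", "known", "first", "only" and "open" are said of these compounds alone.

Working notes on the series built on the core of compound 1 `CC(C)[C@H](NC(=O)COc1cccc2ccccc12)C(=O)N[C@@H](CC(=O)O)C(=O)COc1cccc(C(F)(F)F)c1`. In a functional assay on Jurkat cells (Homo sapiens) (a lower number here means a stronger inhibitor, a higher number a weaker inhibitor), compound 1 gives only a limit, > 100000 nM, sitting at the limit of > 100000 nM in this assay, at which 1 of the 2 values shown sits. Going by the values given here, compound 2 `CC(C)[C@H](NC(=O)COc1cccc2ccccc12)C(=O)N[C@@H](CC(=O)O)C(=O)COc1c(F)ccc(F)c1F` carries 2,3,6-trifluorophenyl in place of 3-(trifluoromethyl)phenyl on an oxygen on a saturated carbon; in this assay compound 2 gives 1200 nM, the only number so far in the set, reached by an at least 83-fold lower number from compound 1 to compound 2 (1.92 log units; beyond the scatter). Compound 3 `CC(C)[C@H](NC(=O)COc1cccc2ccccc12)C(=O)N[C@@H](CC(=O)O)C(=O)COc1c(Cl)cccc1Cl` differs from compound 2 as follows: 2,6-dichlorophenyl in place of 2,3,6-trifluorophenyl on an oxygen on a saturated carbon. Among the compounds with values here, the one measured step at this place, an at least 83-fold lower number from compound 1 to compound 2 (1.92 log units; beyond the scatter), involves a different pair of groups, so it fixes no direction for the present change; it shows only that this position can shift the number a great deal. Within the data shown here, both groups now compared are halogenated phenyl rings, and no measured step separates them. Compound 3 is accordingly expected at 800 nM, range 200 nM to 4000 nM, the expected step of a 1.5-fold lower number from compound 2 to compound 3 (0.18 log units; within the scatter) lying within the scatter.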

Compound 3, half-maximal inhibitory concentration: 3000 nM
Beside the measured number, compound 3's estimate is 3.8-fold (0.57 log units) below it; low and high end bracket the measured number.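

In this assay, this position also separates two halogenated phenyl groups, with a 2.5-fold higher number from compound 2 to compound 3 (0.40 log units; beyond the scatter), so the change from 2,3,6-trifluorophenyl to 2,6-dichlorophenyl is not silent. Against 3-(trifluoromethyl)phenyl, the second halogenated group also reads clearly better, with an at least 33-fold lower number from compound 1 to compound 3 (1.52 log units; beyond the scatter), so the large step seen earlier is not confined to 2,3,6-trifluorophenyl. The value of compound 1 is a limit and not a number: the limit of > 100000 nM in this assay, at which 1 of the 3 values shown sits.

The kind of halogen and the count of halogens change together between compound 2 and compound 3, which leaves open which of the two carries the difference. Also open, going by these compounds, is how a phenyl ring carrying an amine or a nitrile would read at this position on the shared core.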